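This account rests on a few compounds, and the source may have more. Where it says the series, first, only, none or still open, it means among the compounds named here.

In a functional assay on RAW264.7 cells (Mus musculus) for inhibition, read by Griess assay, with stated times of 1 h and 24 h (a higher number here means a weaker inhibitor, a lower number a stronger inhibitor), compound 1 (`Cc1noc(CC2OC(=O)c3ccccc32)n1`) gives > 10000 nM, which is a limit and not a number. Compound 2 (`O=C1OC(Cc2nc(-c3ccccc3)no2)c2ccccc21`) gives > 10000 nM, also a limit. Within the data shown here, the one measured step, a step that the two limits leave unreadable from compound 1 to compound 2, therefore has no readable size. Compound 3 (`CCC(C)Oc1ccc(C(O)C2OC(=O)c3c(OC)cc(OC)cc32)cc1`) gives > 10000 nM, again only a limit. Among the measured compounds shown here, the whole series so far stands at the limit of > 10000 nM in this assay, at which 3 of the 3 values shown sit. Compound 4 (`C=CCCOc1ccc(C(O)C2OC(=O)c3c(OC)cc(OC)cc32)cc1`) differs from compound 3 in one place: but-3-en-1-yl in place of sec-butyl on an oxygen on an aromatic ring. The measured step involves a different change and offers no size to carry over, so the data give no ground for a shift beyond the scatter in this assay. The expected step is a step that the limit leaves unreadable from compound 3 to compound 4, with no direction expected. Compound 4 is estimated at 12000 nM, with an expected range from 4000 nM to 30000 nM.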

Compound 4, half-maximal inhibitory concentration: 1330 nM
Estimate against measurement, compound 4: 9.0-fold (0.96 log units) above; measured number below the stated range.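

In this assay, but-3-en-1-yl in place of sec-butyl on an oxygen on an aromatic ring gives an at least 7.5-fold lower number from compound 3 to compound 4 (0.87 log units; beyond the scatter), so this position does respond to the group it carries, even with the same count of heavy atoms entering and leaving. The entering group adds one double bond outside aromatic rings, and the chain differs in shape as well. Compound 4 is the first compound here with a readable number: the limit of > 10000 nM in this assay, at which 3 of the 4 values shown sit.

The compounds shown leave open whether the double bond or the loss of the branch matters, a question that a saturated n-butyl chain on the same oxygen would address. On these data alone, how a longer chain or an amine would read at this position also remains open.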